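Extending the side chain of compound 1

This account rests on a few compounds, and the source may have more. Where it says the series, first, only, none or still open, it means among the compounds named here.

Compound 1 `C[C@H](NC(=O)CN(c1nc(Cl)nc2[nH]cnc12)C1CC1)C(=O)OCc1ccccc1` stands at the top of three numbers in a functional assay on the whole organism (Tail, strain ICR) with Mus musculus as the target, in the tail flick test, with a stated time of 30 min, at a dose of 25 umol/kg by the oral route (on this read-out higher numbers stand for a stronger effect at the one dose given and lower numbers for a weaker effect), where compound 1 gives 41.2%. Compound 2 `O=C(OCc1ccccc1)[C@@H]1CCCN1C(=O)CN(c1ncnc2c1ncn2C1CCCCO1)C1CC1` gives 32.3% and compound 3 `O=C(CN(c1ncnc2c1ncn2C1CCCCO1)C1CC1)N[C@@H](CC(=O)OCc1ccccc1)C(=O)OCc1ccccc1` gives 31.8%; both of these numbers lie within the usual scatter of compound 1, so the three cannot be ranked. Compound 4 `CSCC[C@H](NC(=O)CN(c1nc(Cl)nc2[nH]cnc12)C1CC1)C(=O)OCc1ccccc1` differs from compound 1 in one place: (methylsulfanyl)methyl in place of hydrogen on a saturated chain carbon, two bonds along the chain from an amide-type nitrogen and a carbonyl carbon. For the measured compounds named here, no step between measured compounds is available, so this change has no precedent in the set. The author expects the step from compound 1 to compound 4 to be a number 1.2 percentage points lower from compound 1 to compound 4 (within the scatter), that is, nothing beyond the scatter in either direction. Compound 4 is therefore estimated at 40%, within a range from 25% to 55%.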

Compound 4, a percentage reported as activity, at one dose (the size of the read-out at that dose, not a potency): 22.2%
Compound 4: middle estimate off by 17.8 percentage points, on the high side, outside the stated range (below it).
By their numbers in this assay, from the lowest: compounds 4, 3, 2 and 1 (each within the scatter of the next, the first and the last beyond it).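

In this assay, (methylsulfanyl)methyl in place of hydrogen on this saturated chain carbon gives a number 19 percentage points lower from compound 1 to compound 4 (beyond the scatter) and so yields the first difference in the set that exceeds the scatter. This shows that the read-out responds to the side chain at this position, and that going from methyl to 2-(methylsulfanyl)ethyl here does not preserve the effect. Nothing available explains the loss.

Whether the sulfur or the chain length accounts for the step stays open, since a plain propyl chain at this carbon would be needed to separate the two. From the compounds shown here alone, how an amine or a carboxylic acid would behave at the same position also remains unknown.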